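The compounds below may be only part of what the source reports. "The series", "measured", "known", "first", "only" and "open" are said of these compounds alone.

Working notes on a four-membered series sharing one core. Compound 1 `COc1cccc(CNCCCNc2ccnc3cc(-c4ccc(C(C)(C)C)cc4)ccc23)c1O` carries a 2-hydroxy-3-methoxybenzyl group on the amine; in a physicochemical assay for solubility, with a stated time of 18 h, at pH 7.4 (a lower number here means a less soluble compound, a higher number a more soluble compound), compound 1 gives 32000 nM. Compound 2 `COc1ccc(F)cc1CNCCCNc1ccnc2cc(-c3ccc(C(C)(C)C)cc3)ccc12` carries a 5-fluoro-2-methoxybenzyl group instead, and in this assay compound 2 gives 32000 nM. Compound 3 `COc1ccc(F)cc1CNCCCNc1ccnc2cc(-c3ccc(C(F)(F)F)cc3)ccc12` keeps that benzyl group but its core differs from the core of compound 2 by trifluoromethyl in place of tert-butyl on an aromatic carbon; in this assay compound 3 gives 32000 nM. The three measured values are level within the scatter, and the two single-point steps, no change at the digits printed from compound 2 to compound 1 (within the scatter) and no change at the digits printed from compound 2 to compound 3 (within the scatter), are both within it.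

Compound 4 `COc1cccc(CNCCCNc2ccnc3cc(-c4ccc(C(F)(F)F)cc4)ccc23)c1O` is not yet measured. It differs from compound 3 by 2-hydroxy-3-methoxyphenyl in place of 5-fluoro-2-methoxyphenyl on a saturated chain carbon bound to an amine nitrogen, the same change as 2-hydroxy-3-methoxyphenyl in place of 5-fluoro-2-methoxyphenyl on a saturated chain carbon bound to an amine nitrogen between compound 2 and compound 1, at the same place. Because no change at the digits printed from compound 2 to compound 1 (within the scatter) lay within the scatter, the corresponding step is expected to be flat as well, no change at the digits printed from compound 3 to compound 4 (within the scatter), so compound 4 is estimated at 32000 nM, with a range from 16000 nM to 64000 nM. This rests on one prior occurrence only.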

Compound 4, solubility: 32000 nM
Compound 4: the middle estimate sits on the measured number at the digits printed, within the range that was stated.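

In this assay the change to 2-hydroxy-3-methoxyphenyl on a saturated chain carbon bound to an amine nitrogen gives no change at the digits printed from compound 3 to compound 4 (within the scatter) on the core of compound 3 and no change at the digits printed from compound 2 to compound 1 (within the scatter) on the core of compound 2, while trifluoromethyl in place of tert-butyl gives no change at the digits printed from compound 1 to compound 4 (within the scatter) with the 2-hydroxy-3-methoxybenzyl group in place. The flat reading therefore carries from one core to the other in this series, and each of the two changes now has two flat occurrences. This covers only these two cores and this one pair of benzyl groups, shows nothing about any other core, and no measurement at hand accounts for the flat steps.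

With no step beyond the scatter, nothing shown yet identifies a part of the structure that can shift the reading in this assay at all. Open, from the compounds shown here alone, are a carboxylic acid or a primary amine on the benzyl group, and a longer chain carrying the amine.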